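A few compounds are considered here, and "the series" means these few. Any claim that something is new, unique, unknown or untested is made for them only; others in the source may bear on it.

In an ADME assay for pharmacokinetics (a higher number here means that the compound lasts longer, a lower number that the compound disappears faster), compound 1 `CCCCC1=Nc2ccccc2S(=O)(=O)N1Cc1ccc(-c2ccccc2C(=O)O)cc1` stands at >> 24 h as a limit of the assay and not a number. For the measured compounds named here, compound 2 `CCCCC1=NS(=O)(=O)c2ccccc2N1Cc1ccc(-c2ccccc2C(=O)O)cc1` gives 0.25 h as the only actual number so far in this assay for the series. Compound 3 `CCCSC1=NS(=O)(=O)c2ccccc2N1Cc1ccc(-c2ccccc2C(=O)O)cc1` carries propylsulfanyl in place of butyl on a carbon with a double bond to nitrogen. Going by the values given here, no measured step bears on this change, so no shift beyond the scatter is expected in either direction. The expected size is a 1.2-fold higher number from compound 2 to compound 3 (0.08 log units; within the scatter) and so stays within the scatter. Compound 3 is estimated at 0.3 h with an expected range of 0.08 h to 1.5 h in this read-out.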

Compound 3, half-life: 3 h
Beside the measured number, compound 3's estimate is 10-fold (1.00 log units) below it; measured number above the stated range.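

In this assay, for the compounds shown here, the carbon with a double bond to nitrogen proves to be a responsive place: propylsulfanyl in place of butyl gives a 12-fold higher number from compound 2 to compound 3 (1.08 log units; beyond the scatter) and is the first measured change here. The two chains have the same count of heavy atoms, so an exchange that leaves this count unchanged is enough to move the read-out. No measurement shown gives a cause for this step. On these data alone, whether the sulfur or the chain as a whole carries the step stays open; a butyloxy chain, an amine or a longer sulfur-linked chain at this place would bear on that.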